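The source may report more compounds than this note shows. Statements on the series, on what has been measured and on what is new or still open speak of the compounds shown alone.

Measured so far in an ADME assay on HepG2 cells (Homo sapiens) for cytotoxicity, read by CellTiter-Glo and resazurin assay, with a stated time of 72 h; a lower number here means that less compound is needed, a higher number that more compound is needed for the effect:
- compound 1 `CCOC(=O)CCCCCOc1cccc(CN(C(=O)c2ccc(-c3cnc(OC)nc3OC)cc2)C(C)C)c1`: > 26000 nM, a limit of the assay
- compound 2 `CCOC(=O)CCCCCOc1cccc(CN(C(=O)c2ccc(-c3ccoc3)cc2)C(C)C)c1`: > 26000 nM, a limit of the assay

Notes on the series. In this assay compound 1 gives > 26000 nM, which is a limit and not a number. Compound 2 gives > 26000 nM, likewise a limit. The change from compound 1 to compound 2, furan-3-yl in place of 2,4-dimethoxypyrimidin-5-yl on an aromatic carbon, therefore yields a step that cannot be read, a step that the two limits leave unreadable from compound 1 to compound 2. Where compound 2 stands is given only by the limit of > 26000 nM in this assay, at which 2 of the 2 values shown sit; both values shown sit there, so no number places compound 2 within the measured range.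

Compound 3 `CCOC(=O)CCCCCOc1cccc(CN(C(=O)c2ccc(-c3cccc(OC(C)C)c3)cc2)C(C)C)c1` differs from compound 2 as follows: 3-isopropoxyphenyl in place of furan-3-yl on an aromatic carbon. Within the data shown here, only one measured step bears on a change at this place, and its size is not readable, so no direction can be taken from it. The expectation for compound 3 is that it too remains at the limit of this assay. Compound 3 is estimated at 30000 nM, with a range from 12000 nM to 80000 nM. The step from compound 2 to compound 3 is thus expected to be none beyond the scatter, a step that the limit leaves unreadable from compound 2 to compound 3.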

Compound 3, half-maximal effective concentration: > 26000 nM
Compound 3: no number, only a limit; the forecaster's own chance of this, stated with the estimate: 75%; the middle value does not contradict the limit.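

Compound 3 joins compound 1 and compound 2 at the limit in this assay, so no step among these three compounds can be read: the limit of > 26000 nM in this assay, at which 3 of the 3 values shown sit.

The compounds shown leave open whether any of the three groups on this aromatic carbon differs from another in half-maximal effective concentration, as none of the three compounds has a number.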